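The compounds below may be only part of what the source reports. "The series", "measured", "known", "first", "only" and "open" are said of these compounds alone.

Of the compounds shown here, two of a shared core have been measured. Compound 1, `O=C(CCCCCCc1ccc(Cl)cc1)N1CCCC1`, carries a chlorophenyl at the end of a long chain, and in an assay on HEK293 cells for inhibition of N-acylethanolamine-hydrolyzing acid amidase (Rattus norvegicus), read by LC-MS, with a stated time of 30 min (a lower number here means a stronger inhibitor, a higher number a weaker inhibitor), compound 1 gives 34500 nM. Compound 2, `O=C(CCc1ccc(-c2cccc(F)c2)cc1)N1CCCC1`, has a shorter chain ending in a pair of joined aromatic rings, and in this assay compound 2 gives 1800 nM. Of the two numbers, compound 2 gives the lower one, and the gap between compound 2 and compound 1 lies beyond the usual scatter of repeated measurements, so compound 2 is the stronger inhibitor of the pair.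

Compound 3, `O=C(CCc1ccc(C2CCCCC2)cc1)N1CCCC1`, is the next compound in this line. It differs from compound 2 in one place: cyclohexyl in place of 3-fluorophenyl on an aromatic carbon. Going by the values given here, no measured pair shows what such a change does, so the expectation rests only on compound 2 and the change itself. The outer ring keeps its size but loses its aromatic character and its fluorine. A small step toward a higher number is expected, roughly at the edge of the scatter, so that compound 3 is expected to give 3500 nM, within a range from 1200 nM to 10000 nM, and the step of a 1.9-fold higher number from compound 2 to compound 3 (0.29 log units; within the scatter) is expected to be modest.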

Compound 3, half-maximal inhibitory concentration: 500 nM
Beside the measured number, compound 3's estimate is 7.0-fold (0.85 log units) above it; the whole stated range lies above it.
By their numbers in this assay, from the lowest: compound 3; then compound 2; then compound 1.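

Putting cyclohexyl in place of 3-fluorophenyl on this aromatic carbon gives, in this assay, a 3.6-fold lower number from compound 2 to compound 3 (0.56 log units; beyond the scatter), so at this position an outer ring needs neither aromatic character nor a fluorine for inhibition to be retained, and the non-aromatic ring is in fact the better of these two. Going by these compounds alone, this is the first step that changes a single place, which the gap between the two earlier compounds, differing in both chain and end group, could not offer. The change removes the aromatic character and the fluorine together and leaves one heavy atom fewer, and nothing available here explains why the number fell.

On these data alone, a plain phenyl group, without fluorine, would help separate the loss of the fluorine from the loss of the aromatic ring, so the share of each in this step remains open. Also open, as far as these compounds go, is how far the finding extends: whether a smaller ring such as cyclopentyl, a ring holding an amine such as piperidinyl, or a cyclohexyl group on a longer chain would keep the lower number.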